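Bridged diamine series: hydroxy to fluoro on the anilino ring

This account rests on a few compounds, and the source may have more. Where it says the series, first, only, none or still open, it means among the compounds named here.

Compound 2 `Oc1ccc(Nc2cncc(N3CC4CC(C3)N4)c2)cc1` gives 0.342 nM in an assay on cell membranes for displacement of a labelled ligand from Neuronal acetylcholine receptor; alpha4/beta2 (Rattus norvegicus) (on this read-out lower numbers stand for stronger inhibition and higher numbers for weaker inhibition), and stands lowest of the three measured compounds; compound 1 `c1ccc(Nc2ccc(N3CC4CC(C3)N4)nn2)cc1` gives 441 nM and compound 3 `Clc1cccc(Nc2ccc(N3CC4CC(C3)N4)nn2)c1` gives 1540 nM, both on a different core and both beyond the scatter above it. Compound 4 `Fc1ccc(Nc2cncc(N3CC4CC(C3)N4)c2)cc1` differs from compound 2 by fluoro in place of hydroxy on an aromatic carbon. Among the compounds with values here, the only measured step, a 3.5-fold higher number from compound 1 to compound 3 (0.54 log units; beyond the scatter), concerns another position and another group, so no direct precedent exists for replacing the hydroxy. With its donor and acceptor removed, compound 4 is expected to be weaker than compound 2 by an 8.8-fold higher number from compound 2 to compound 4 (0.94 log units; beyond the scatter), a moderate loss. The estimated value for compound 4 is 3 nM, with a range from 0.7 nM to 15 nM.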

Compound 4, inhibition constant: 0.091 nM
Beside the measured number, compound 4's estimate is 33-fold (1.52 log units) above it, outside the stated range (below it).
By their numbers in this assay, from the lowest: compound 4; then compound 2; then compound 1; then compound 3.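

Fluoro in place of hydroxy gives a 3.8-fold lower number from compound 2 to compound 4 (0.57 log units; beyond the scatter) on the shared core, so on this evidence 4-hydroxyphenyl is not required for a low number here. The hydrogen-bond donor and acceptor counted for hydroxy can leave this aromatic carbon without a rise in the number, and fluoro, which counts neither, is the better of the two groups measured at this place. No measurement at hand accounts for this step.

On these data alone, whether an amine, a methoxy group or a carboxylic acid at this place would match fluoro remains open. Also open, as far as these compounds go, is how plain hydrogen at this place on the shared core compares with either group.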